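Longer Alkoxy Chains Leave This Weak Inhibition Unchanged

This account rests on a few compounds, and the source may have more. Where it says the series, first, only, none or still open, it means among the compounds named here.

Compound 1 `CCCCOc1cc(OC)ccc1C(C)=O` gives 43300000 nM in a functional assay, with a stated time of 30 min; a higher number here means a weaker inhibitor, a lower number a stronger inhibitor.
Compound 2 `CCCCCCOc1cc(OC)ccc1C(C)=O` gives 42600000 nM in this assay.
Compound 3 `CCCCCCCCCCCCOc1cc(OC)ccc1C(C)=O` gives 37400000 nM in this assay.

The change ethyl in place of hydrogen on a saturated chain carbon, four bonds along the chain from an oxygen on an aromatic ring produced a 1.0-fold lower number from compound 1 to compound 2 (0.01 log units; within the scatter). The steps of a 1.2-fold lower number from compound 1 to compound 3 (0.06 log units; within the scatter) and a 1.1-fold lower number from compound 2 to compound 3 (0.06 log units; within the scatter) are likewise within the scatter. Compound 4 `CCCCCCCCCCCCCCOc1cc(OC)ccc1C(C)=O` has not been measured; it differs from compound 3 by ethyl in place of hydrogen on a saturated chain carbon, ten or more bonds along the chain from an oxygen on an aromatic ring. This is the same kind of change as that from compound 1 to compound 2, but the place on the chain differs. The two cores differ by octyl in place of hydrogen on a saturated chain carbon, four bonds along the chain from an oxygen on an aromatic ring. Because a 1.0-fold lower number from compound 1 to compound 2 (0.01 log units; within the scatter) lay within the scatter and a 1.2-fold lower number from compound 1 to compound 3 (0.06 log units; within the scatter) did as well, compound 4 is expected to stay within the scatter of compound 3, with an estimated step of a 1.0-fold lower number from compound 3 to compound 4 (0.02 log units; within the scatter). In this assay compound 4 is estimated at 36000000 nM, between 18000000 nM and 72000000 nM.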

Compound 4, half-maximal inhibitory concentration: 43600000 nM
Beside the measured number, compound 4's estimate is 1.2-fold (0.08 log units) below it; the range from low to high includes it.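

In this assay, the ethyl change at the far end of the chain gives a 1.2-fold higher number from compound 3 to compound 4 (0.07 log units; within the scatter), and this matches the same change made nearer the oxygen: the same change on two cores in this assay, a 1.0-fold lower number (0.01 log units; within the scatter) from compound 1 to compound 2 and a 1.2-fold higher number (0.07 log units; within the scatter) from compound 3 to compound 4, 1.2-fold (0.07 log units) apart, within the scatter of two such steps. The octyl change gives a 1.0-fold higher number from compound 2 to compound 4 (0.01 log units; within the scatter), and this also matches its earlier counterpart: the same change on two cores in this assay, a 1.2-fold lower number (0.06 log units; within the scatter) from compound 1 to compound 3 and a 1.0-fold higher number (0.01 log units; within the scatter) from compound 2 to compound 4, 1.2-fold (0.07 log units) apart, within the scatter of two such steps. Both changes therefore carry from one core to another only as steps within the scatter, which does not show whether a step beyond the scatter would carry over, and no such step appears among these compounds.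

Going by these compounds, it remains open whether a chain longer than that of compound 4 would stay within the scatter. On these data alone, it is also open whether a chain ending in an amine or a carboxylic acid would do so.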